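Epimer of a brominated lactone in a cytotoxicity assay

This account rests on a few compounds, and the source may have more. Where it says the series, first, only, none or still open, it means among the compounds named here.

Measured so far:
compound 1, `CCC[C@@H](OC(C)=O)C1=C(Br)[C@@](CI)(OC)OC1=O`: 12.9 ug/mL
compound 2, `CCC[C@@H](OC(C)=O)C1=C(Br)[C@@](OC)(C(Br)Br)OC1=O`: 3.6 ug/mL

In a functional assay on LNCaP cells (Homo sapiens) for cytotoxicity (on this read-out higher numbers stand for an effect only at larger amounts of compound and lower numbers for an effect already at smaller amounts), compound 2 gives 3.6 ug/mL, the lower of the two numbers shown. Compound 1 gives 12.9 ug/mL in this assay, and its gap to compound 2 lies beyond the usual scatter. Compound 3 `CCC[C@@H](OC(C)=O)C1=C(Br)[C@](OC)(C(Br)Br)OC1=O` has not yet been measured in this assay. Compared with compound 2, (the two compounds have the same atoms and bonds and differ only in configuration as drawn: 1 of 2 stereo elements differ; a stereocentre at a saturated ring carbon is drawn S in compound 2 and R in compound 3).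

Among the measured compounds shown here, no pair of measured compounds differs only in configuration, so the data give no direct guide to what such a change does here. The expectation rests on compound 2 alone, whose number is 3.6 ug/mL in this assay. The step of a 1.5-fold higher number from compound 2 to compound 3 (0.18 log units; within the scatter) is expected to be modest, toward a somewhat higher number, with wide uncertainty. Compound 3 is estimated at 5.5 ug/mL in this assay, within a range from 2 ug/mL to 16 ug/mL.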

Compound 3, concentration for half-maximal effect: 4.5 ug/mL
Compound 3: the middle estimate sits 1.2-fold (0.09 log units) above what was measured; measured number inside the range.
By their numbers in this assay, from the lowest: compounds 2 and 3 (each within the scatter of the next); then compound 1.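

In this assay, the configuration at this saturated ring carbon carries little weight: drawing the stereocentre R rather than S gives a 1.3-fold higher number from compound 2 to compound 3 (0.10 log units; within the scatter), so the two forms cannot be told apart on this read-out. The group on that same carbon counts for more, with dibromomethyl in place of iodomethyl giving a 2.9-fold lower number from compound 1 to compound 3 (0.46 log units; beyond the scatter), a step beyond the scatter. The reading of the first step as a pure test of configuration is secure on one point: the fact that compounds 2 and 3 differ only in the configuration as drawn

The compounds shown leave open whether the second stereo element, which compound 2 and compound 3 share, matters as little as this one. They also leave open how the read-out would respond to a hydroxymethyl group or a carboxylic acid on the ring carbon in place of dibromomethyl.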